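Swapping 3,4-dimethoxyphenyl for 4-fluorophenyl

This account rests on a few compounds, and the source may have more. Where it says the series, first, only, none or still open, it means among the compounds named here.

Among the measured compounds shown here, in a functional assay on ZR-75-1 cells (Homo sapiens) for inhibition, read by sulforhodamine B assay (a lower number here means a stronger inhibitor of growth, a higher number a weaker inhibitor of growth), compound 1 (`COc1ccc(-c2ccc(-c3ccc(-c4nc5cc(C)ccc5[nH]4)cc3)cc2)cc1OC`) gives 3100 nM at the high end of the three numbers known so far, level with compound 3 (`COc1ccc(-c2ccc(-c3ccc(-c4nc5c(O)cccc5[nH]4)cc3)cc2)cc1OC`) at 2110 nM within the scatter. That pair differs in another group, and a 1.5-fold lower number from compound 1 to compound 3 (0.17 log units; within the scatter) says little about the present change. Compound 2 (`COc1cc(-c2ccc(-c3ccc(-c4nc5cc(C)ccc5[nH]4)cc3)cc2)cc(OC)c1OC`) gives 190 nM and matters more: one extra methoxy on the ring that changes now gave a 16-fold lower number from compound 1 to compound 2 (1.21 log units; beyond the scatter) so a wide range is needed. Compound 4 (`Cc1ccc2[nH]c(-c3ccc(-c4ccc(-c5ccc(F)cc5)cc4)cc3)nc2c1`) carries 4-fluorophenyl in place of 3,4-dimethoxyphenyl on an aromatic carbon as 4-fluorophenyl in place of 3,4-dimethoxyphenyl. For the measured compounds named here, it holds no methoxy, and no measured compound holds fluorine, so the direction stays open. Only a modest move is expected, with a 1.2-fold lower number from compound 1 to compound 4 (0.09 log units; within the scatter) as the estimated step. Compound 4 is estimated at 2500 nM with an expected range of 700 nM to 9000 nM for now.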

Compound 4, concentration for 50% growth inhibition: 35000 nM
Beside the measured number, compound 4's estimate is 14-fold (1.15 log units) below it; measured number above the stated range.
By their numbers in this assay, from the lowest: compound 2; then compounds 3 and 1 (each within the scatter of the next); then compound 4.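

In this assay, swapping 3,4-dimethoxyphenyl for 4-fluorophenyl gives an 11-fold higher number from compound 1 to compound 4 (1.05 log units; beyond the scatter). With a 16-fold lower number from compound 1 to compound 2 (1.21 log units; beyond the scatter), this shows that changes on this ring can shift growth inhibition strongly in either direction from compound 1. No available evidence explains the loss seen with compound 4. The swap removes both methoxy groups and adds fluorine in one step, and the compounds shown cannot separate those two parts. An unsubstituted phenyl ring or a ring carrying an amine at the same place would remain to be compared.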